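A few compounds are considered here, and "the series" means these few. Any claim that something is new, unique, unknown or untested is made for them only; others in the source may bear on it.

Measured compounds:
- compound 1 `COc1ccccc1/C=C/C(=O)/C=C/c1ccc(OCc2cn(CCOc3cc(=O)oc4ccccc34)nn2)c(OC)c1`: 11%
- compound 2 `COc1cc(/C=C/C(=O)/C=C/c2ccco2)ccc1OCc1cn(CCCCOc2cc(=O)oc3ccccc23)nn1`: "not active" (no number reported)

Both compounds were tested in a functional assay on PC-3 cells (Homo sapiens) for inhibition, read by sulforhodamine B assay, with a stated time of 48 h, tested at 50 uM; a lower number here means less inhibition of growth, a higher number more inhibition of growth at the concentration tested. Compound 1 gives 11% in this assay, a small effect at the concentration used. Compound 2 is reported in this assay only as "not active" (no number reported), so no single number stands for it; all that can be said is that it shows no measurable inhibition of growth, which places it at or near the low end of what compound 1 shows.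

The next compound, compound 3 `COc1cc(/C=C/C(=O)/C=C/c2ccccc2)ccc1OCc1cn(CCCCOc2cc(=O)oc3ccccc23)nn1`, differs from compound 2 in one place: phenyl in place of furan-2-yl on a double-bonded chain carbon bound to a double-bonded chain carbon. Among the measured compounds shown here, no measured pair with this change is available, so the size of the step can only be guessed. Given that compound 2 is reported as inactive and compound 1, the only compound with a number, sits low in this assay, the change is expected to move the read-out in this assay by no more than the usual scatter, if at all, in either direction. Compound 3 is therefore expected to give about 8% in this assay, within a range from 0% to 20%.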

Compound 3, percent growth inhibition at one concentration: "not active" (no number reported)
Compound 3: no number reported, and the estimate cannot be compared.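

Compound 2 and compound 3 are both reported in this assay without a number, so no step can be read for the change from furan-2-yl to phenyl. No evidence shown bears on this result. The compounds shown leave open whether this change alters growth inhibition at all under conditions that yield a number.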